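Fluoro-for-hydrogen steps in an antiproliferative series

The source may hold more compounds than are shown below. What is called first, only, known or untested is meant among the compounds shown, and "the series" means these compounds.

Compound 1 `Cc1cc(OCc2nnc(SCc3ccccc3)o2)cc2oc(=O)cc(C)c12` and compound 2 `Cc1cc(OCc2nnc(SCc3cccc(F)c3)o2)cc2oc(=O)cc(C)c12` share one core, and compound 3 `Cc1cc(OCc2nnc(S(=O)(=O)Cc3cccc(F)c3)o2)cc2oc(=O)cc(C)c12` carries a second one that also sits in compound 4 `Cc1cc(OCc2nnc(S(=O)(=O)Cc3ccc(F)c(F)c3)o2)cc2oc(=O)cc(C)c12`, the compound still to be measured. The difference between the two cores is not broken down here. All four are followed in a functional assay on MDA-MB-231 cells (Homo sapiens) for antiproliferative activity, read by MTT assay, with a stated time of 24 h; a lower number here means a stronger inhibitor, a higher number a weaker inhibitor.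

In this assay compound 1 gives only a limit, > 100000 nM. Compound 2 likewise gives only a limit, > 100000 nM. The change between them is fluoro in place of hydrogen on an aromatic carbon, and its step that the two limits leave unreadable from compound 1 to compound 2 cannot be sized, since both values sit at the limit of > 100000 nM in this assay, at which 2 of the 3 values shown sit. Going by the values given here, compound 3 is the one compound with a number: in this assay compound 3 gives 21300 nM.

From compound 3 to compound 4 the change is fluoro in place of hydrogen on an aromatic carbon. Among the compounds with values here, it is the same kind of change as the one from compound 1 to compound 2, not the same: there the entering fluoro sat meta to a large group, here it sits ortho to a fluoro group and para to a large group.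

With the earlier step unreadable, the expectation rests on compound 3 at 21300 nM alone, and the step expected is small, a 1.3-fold lower number from compound 3 to compound 4 (0.12 log units; within the scatter). Compound 4 is therefore expected near 16000 nM, within 5000 nM to 50000 nM.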

Compound 4, half-maximal inhibitory concentration: 31600 nM
Estimate against measurement, compound 4: 2.0-fold (0.30 log units) below; low and high end bracket the measured number.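

In this assay, the fluoro step on the second core reads as a 1.5-fold higher number from compound 3 to compound 4 (0.17 log units; within the scatter), so adding a second fluoro to the 3-fluorobenzyl group, to give the 3,4-difluorobenzyl group, leaves the number within the scatter on this core. The fluoro step on the core of compound 1 cannot be read, because both of its values are limits and not numbers: the limit of > 100000 nM in this assay, at which 2 of the 4 values shown sit. Going by these compounds alone, the transfer of this change between cores therefore remains untested: only one of the two steps has a size, so neither agreement nor disagreement between the cores can be claimed, and the two steps also differ in where the fluoro enters.

Open, on these data alone, is how the plain benzyl group reads on the core of compound 3, a value that would give a fluoro step on that core matching the step from compound 1 to compound 2 in place. As far as these compounds go, compound 3 stands at 21300 nM, and also open is whether a methoxy group, an amine or a carboxylic acid on the benzyl ring, or a longer chain in place of the benzyl group, would move the number beyond the scatter.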